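The source may report more compounds than this note shows. Statements on the series, on what has been measured and on what is new or still open speak of the compounds shown alone.

Three compounds of the series carry numbers in a physicochemical assay for acid dissociation. Compound 1 `CC(=O)Nc1ccc(OC(=S)Nc2ccc(Nc3ccc(C(Cl)(Cl)Cl)cc3)cc2)cc1` gives 9.01 in this assay. Compound 2 `Oc1ccc(OC(=S)Nc2ccc(Nc3ccc(C(F)(F)F)cc3)cc2)cc1` gives 9.23. Compound 3 `CC(=O)Nc1ccc(OC(=S)Nc2ccc(Oc3ccc([N+](=O)[O-])cc3)cc2)cc1` gives 9.04, the second highest of the three numbers; the nearest number belongs to compound 1 and the furthest to compound 2, and both gaps fall within the usual scatter, so the three measured compounds cannot be separated on this read-out. For the measured compounds named here, no two measured compounds differ in one place only, so no single step has yet been isolated.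

Compound 4 `CC(=O)Nc1ccc(OC(=S)Nc2ccc(Nc3ccc([N+](=O)[O-])cc3)cc2)cc1` has not been measured. Against compound 3 the change is (4-nitrophenyl)amino in place of 4-nitrophenoxy on an aromatic carbon. Nothing measured speaks for a large effect of this change: compound 1 with 9.01 and compound 3 with 9.04 lie within the scatter of each other. The step is therefore expected to be small, not beyond the scatter, at a number 0.01 log units higher from compound 3 to compound 4 (within the scatter). Compound 4 is estimated at 9.05, in a range from 8.75 to 9.35.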

Compound 4, acid dissociation constant: 9.04
For compound 4 the middle estimate is 0.01 log units above the measured one, within the range that was stated.
By their numbers in this assay, from the lowest: compounds 1, 3, 4 and 2 (each within the scatter of the next).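

In this assay, (4-nitrophenyl)amino in place of 4-nitrophenoxy on an aromatic carbon para to a large group gives no change at the digits printed from compound 3 to compound 4 (within the scatter), so the first step isolated at this position cannot be told from repeat measurement. Compound 4 also allows a second single-place comparison: nitro in place of trichloromethyl on an aromatic carbon gives a number 0.03 log units higher from compound 1 to compound 4 (within the scatter), and this exchange likewise cannot be resolved on this read-out. No supporting measurement bears on the origin of either result.

On these data alone, both steps cover only a narrow set of groups, so it remains open whether a carboxylic acid or a primary amine in place of nitro would give a step beyond the scatter. A thioether or methylene link in place of the amino link also remains untested in the compounds shown.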